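Methoxy for methyl on the aryl ketone of compound 1

The source may hold more compounds than are shown below. What is called first, only, known or untested is meant among the compounds shown, and "the series" means these compounds.

Of the compounds shown here, three have been measured in a functional assay on HT-29 cells (Homo sapiens) for inhibition, read by WST assay, with a stated time of 48 h; on this read-out higher numbers stand for weaker inhibition and lower numbers for stronger inhibition. Compound 1 `Cc1ccc(C(=O)CSc2nc3ccccc3[nH]2)cc1` gives 34500 nM in this assay. Compound 2 `COc1ccccc1C(=O)CSc1nc2ccccc2[nH]1` gives 36100 nM in this assay, and compound 3 `COc1ccc(C(=O)CSc2nc3ccccc3[nH]2)c(OC)c1OC` gives 18800 nM there. Among these three numbers compound 1 stands second highest; its gap to compound 2 lies within the scatter, and so does its gap to compound 3, so none of the three values can be told apart from the others.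

Compound 4 `COc1ccc(C(=O)CSc2nc3ccccc3[nH]2)cc1` has not yet been measured in this assay. It differs from compound 1 by methoxy in place of methyl on an aromatic carbon. Within the data shown here, no pair of measured compounds shows this exchange alone, so no measured step is available for it. Compound 2 and compound 3 also carry methoxy groups on the ring that bears the ketone, and neither of their numbers is separated from that of compound 1 by more than the scatter, so no direction can be read from them. The step from compound 1 to compound 4 is therefore expected to be small, a 1.2-fold lower number from compound 1 to compound 4 (0.06 log units; within the scatter), without a clear direction and not beyond the scatter. Compound 4 is estimated to give about 30000 nM in this assay, within a range of 14000 nM to 65000 nM.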

Compound 4, half-maximal inhibitory concentration: 25200 nM
Estimate against measurement, compound 4: 1.2-fold (0.08 log units) above; the range from low to high includes it.
By their numbers in this assay, from the lowest: compounds 3, 4, 1 and 2 (each within the scatter of the next).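

In this assay, the exchange at this place, on an aromatic carbon para to a large group, now has a direct reading: methoxy in place of methyl gives a 1.4-fold lower number from compound 1 to compound 4 (0.14 log units; within the scatter) and so cannot be told apart from the scatter. Unlike the numbers of compounds 2 and 3, which carry other changes as well, this step isolates the single exchange, so the result applies to this place alone. On this read-out, the added oxygen and the hydrogen-bond acceptor that enter with the methoxy bring no separable change from the methyl of compound 1, and nothing measured here speaks to a cause for this step.

The compounds shown leave open whether any group at this place can move the number beyond the scatter, for example an amine, a carboxylic acid or a longer chain such as butoxy. They also leave open whether a change elsewhere on the shared core, away from the ring that bears the ketone, would separate from the narrow band of values seen so far.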